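The compounds below may be only part of what the source reports. "The series", "measured", "known", "first", "only" and "open" are said of these compounds alone.

Compound 1 `CCCCC(CCO)n1cnc2c(Cl)ncnc21` was tested in a functional assay on HCT-116 cells (Homo sapiens) for antiproliferative activity, read by MTT assay, with a stated time of 48 h (a lower number here means a stronger inhibitor, a higher number a weaker inhibitor), and reached only the limit of the assay, giving > 50000 nM. Compound 2 `CCCCCCCCCCCCC(CCO)n1cnc2c(Cl)ncnc21` likewise stops at a limit, with > 50000 nM in this assay. The change a step that the two limits leave unreadable from compound 1 to compound 2 therefore cannot be read, and the limit of > 50000 nM in this assay, at which 2 of the 2 values shown sit, is all the measured pair shows. Compound 3 `OCCC(CO)n1cnc2c(Cl)ncnc21` differs from compound 1 by hydroxy in place of propyl on a saturated chain carbon, two bonds along the chain from an aromatic nitrogen. Among the compounds with values here, no measured step bears on this change, so the outcome is expected to stay near the limit. The step that the limit leaves unreadable from compound 1 to compound 3 is an estimate only. Compound 3 is expected at 60000 nM, within 20000 nM to 200000 nM, most likely again reported as a limit.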

Compound 3, half-maximal inhibitory concentration: > 50000 nM
Compound 3: a limit, no number; the forecaster's own chance of this, stated with the estimate: 85%; the middle value does not contradict the limit.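

In this assay, within the data shown here, compound 3 gives > 50000 nM, a limit and not a number, and like compound 1 it stops there, so no step between compound 1 and compound 3 can be read. The compounds shown leave open what change to the shared core, if any, would give a measurable value: the limit of > 50000 nM in this assay, at which 3 of the 3 values shown sit.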